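Trimming the Alkyl Group: From Compound 3 to Compound 4

The source may report more compounds than this note shows. Statements on the series, on what has been measured and on what is new or still open speak of the compounds shown alone.

Measured compounds:
compound 1, `O=C(O)c1ccccc1-c1ccc(CCc2ncc(CCC3CCCCC3)[nH]2)cc1`, 642 nM
compound 2, `O=C(O)c1ccccc1-c1ccc(CCc2ncc(Cc3ccccc3Cl)[nH]2)cc1`, 292 nM
compound 3, `CCC(C)(CC)Cc1cnc(CCc2ccc(-c3ccccc3C(=O)O)cc2)[nH]1`, 76 nM

All three were tested in an in vitro functional assay on cells for agonist activity at Bombesin receptor subtype-3 (Homo sapiens), read by luminescence and calcium flux; on this read-out higher numbers stand for an effect only at larger amounts of compound and lower numbers for an effect already at smaller amounts. Compound 3 has the lowest number of the three: compound 2 stands a 3.8-fold lower number from compound 2 to compound 3 (0.58 log units; beyond the scatter) away, and compound 1 stands an 8.4-fold lower number from compound 1 to compound 3 (0.93 log units; beyond the scatter) away, both beyond the scatter. Compound 2 in turn differs from compound 1 by a 2.2-fold lower number from compound 1 to compound 2 (0.34 log units; beyond the scatter).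

Compound 4, `O=C(O)c1ccccc1-c1ccc(CCc2ncc(CC3CC3)[nH]2)cc1`, has not yet been measured. The change from compound 3 is cyclopropyl in place of 1-ethyl-1-methylpropyl on a saturated chain carbon bound to an aromatic carbon. Within the data shown here, the group that enters is smaller than any of the three groups measured at this place, so no measured step covers it directly. What the measured steps do show is that this position moves the number well beyond the scatter: the steps into compound 3, an 8.4-fold lower number from compound 1 to compound 3 (0.93 log units; beyond the scatter) and a 3.8-fold lower number from compound 2 to compound 3 (0.58 log units; beyond the scatter), are the largest in the set, and both replace a group of lower potency with 1-ethyl-1-methylpropyl. Removing that group and leaving only cyclopropyl is therefore expected to cost activity, with a step of about an 11-fold higher number from compound 3 to compound 4 (1.02 log units; beyond the scatter) toward a higher number in this assay. Compound 4 is accordingly estimated at 800 nM, within a range from 200 nM to 3000 nM.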

Compound 4, half-maximal effective concentration: 1000 nM
Compound 4: middle estimate off by 1.3-fold (0.10 log units), on the low side, and the stated range covers the measured number.
By their numbers in this assay, from the lowest: compound 3; then compound 2; then compounds 1 and 4 (each within the scatter of the next).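

In this assay, putting cyclopropyl in place of 1-ethyl-1-methylpropyl on a saturated chain carbon bound to an aromatic carbon gives the largest step yet seen at this place (a 13-fold higher number from compound 3 to compound 4 (1.12 log units; beyond the scatter)). The low number of compound 3 is therefore lost when this group is replaced by cyclopropyl, and 2-chlorophenyl also stands apart from cyclopropyl (a 3.4-fold higher number from compound 2 to compound 4 (0.53 log units; beyond the scatter)). Cyclopropyl and cyclohexylmethyl, however, cannot be told apart (a 1.6-fold higher number from compound 1 to compound 4 (0.19 log units; within the scatter)), so among the four compounds only compound 3 and compound 2 separate from that pair, and the two ring-bearing saturated groups in compound 1 and compound 4 give no order of their own.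

The compounds shown leave open whether a smaller open-chain group such as tert-butyl or isobutyl would keep the low number of compound 3, and how a hydroxyl or an amine on that chain would read in this assay. Nothing given here accounts for the size of these steps.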